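This account rests on a few compounds, and the source may have more. Where it says the series, first, only, none or still open, it means among the compounds named here.

In a functional assay on KB-VIN10 cells (Homo sapiens) for inhibition, with a stated time of 72 h (a lower number here means a stronger inhibitor, a higher number a weaker inhibitor), compound 1 `COc1ccc(S(=O)(=O)N2CCc3cccc(-c4ccc(F)c(F)c4)c32)cc1` gives 46 nM and compound 2 `COc1ccc(S(=O)(=O)N2CCc3cccc(-c4cccc(F)c4)c32)cc1` gives 92.4 nM so these two numbers lie within the usual scatter of each other and cannot be ranked. Among the compounds with values here, compound 2 therefore stands level with the only other measured compound. The next compound is compound 3 `COc1ccc(S(=O)(=O)N2CCc3cccc(-c4ccc(C#N)cc4)c32)cc1` which carries 4-cyanophenyl in place of 3-fluorophenyl on an aromatic carbon of the shared core (4-cyanophenyl in place of 3-fluorophenyl on an aromatic carbon). Within the data shown here, only one measured step bears on this change. That step is a 2.0-fold higher number from compound 1 to compound 2 (0.30 log units; within the scatter) and it comes from hydrogen in place of fluoro on an aromatic carbon. It is small, but it is only a partial guide, since neither measured compound carries a nitrile. With no measured step beyond the scatter, no shift in either direction can be predicted with confidence, though the uncertainty is wide. The estimated outcome is a 1.0-fold lower number from compound 2 to compound 3 (0.01 log units; within the scatter) and so no real change is expected. For compound 3 the expected value is 90 nM with an estimated range from 25 nM to 320 nM in this assay once it is measured.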

Compound 3, half-maximal inhibitory concentration: 29.2 nM
The estimate for compound 3 lay 3.1-fold (0.49 log units) above the measured number, and the stated range covers the measured number.
By their numbers in this assay, from the lowest: compounds 3, 1 and 2 (each within the scatter of the next, the first and the last beyond it).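

In this assay, replacing 3-fluorophenyl with 4-cyanophenyl on the shared core gives a 3.2-fold lower number from compound 2 to compound 3 (0.50 log units; beyond the scatter). Within the data shown here, this is the first step to pass beyond the scatter, so the group at this position can change the measured number, and a nitrile on the phenyl ring is compatible with nanomolar inhibition in these cells. Replacing 3,4-difluorophenyl with 4-cyanophenyl gives a 1.6-fold lower number from compound 1 to compound 3 (0.20 log units; within the scatter), so these two groups cannot be ranked, and no data are available to explain why the nitrile-bearing compound differs from the monofluoro compound.

The step from 3-fluorophenyl to 4-cyanophenyl changes both the group on the phenyl ring and its place on that ring, so it cannot show whether the nitrile itself or its new location matters more. The compounds shown also leave open how this position would respond to very different groups on the ring, such as an amine or a carboxylic acid.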